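Aminophenyl for Phenylethyl on a Brominated Amide Core

The compounds below may be only part of what the source reports. "The series", "measured", "known", "first", "only" and "open" are said of these compounds alone.

Compound 1, `C[C@@H](Nc1c(C(=O)NCc2ccc(F)cc2)nc(Br)c2cccnc12)c1ccccc1`: in a functional assay on HCT-116 cells (Homo sapiens) for cytotoxicity, read by MTT assay, with a stated time of 72 h (on this read-out higher numbers stand for weaker inhibition and lower numbers for stronger inhibition), compound 1 gives > 20000 nM, a limit of the assay rather than a number.
Compound 2, `N[C@H]1CC[C@H](Nc2c(C(=O)NCc3cccc(C(F)(F)F)c3)nc(Br)c3cccnc23)CC1`: in this assay compound 2 gives "not determined" (no result reported).
Compound 3, `C[C@H](CO)Nc1nc(C(=O)NCc2ccc(F)cc2)c(O)c2ncccc12`: in this assay compound 3 gives "not determined" (no result reported).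

Within the data shown here, compound 1 therefore stands at the limit of > 20000 nM in this assay, at which 1 of the 3 values shown sits, and no other compound of the set supplies a number beside it. Compound 4, `Nc1cccc(Nc2c(C(=O)NCc3ccc(F)cc3)nc(Br)c3cccnc23)c1`, has not yet been tested in this assay. It differs from compound 1 in one place, (3-aminophenyl in place of 1-phenylethyl on a nitrogen on an aromatic ring). Among the measured compounds shown here, no measured pair in the set differs in a single place, so no step is available to set the size of this change. With compound 1 sitting at a limit, the account can only reason from that limit: an expected outcome for compound 4 is one in which the step that the limit leaves unreadable from compound 1 to compound 4 lies within the scatter, meaning no change that the assay can resolve. On that basis compound 4 is expected to give about 25000 nM in this assay, with a range from 5000 nM to 100000 nM, and a fair chance that the assay again reports only a limit.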

Compound 4, half-maximal inhibitory concentration: > 10000 nM
Compound 4 ended at the assay's limit; the forecaster's own chance of this, stated with the estimate: 65%; the middle value is on the limit's open side.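

The step from compound 1 to compound 4 cannot be read: both compounds rest on limits of this assay, not on numbers. The compounds shown leave open how strong either compound is, and whether 3-aminophenyl in place of 1-phenylethyl changes the read-out at all.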